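Trading methyl for trifluoromethoxy in a well-tolerated compound

The compounds below may be only part of what the source reports. "The series", "measured", "known", "first", "only" and "open" are said of these compounds alone.

In an ADME assay on CHO cells (Cricetulus griseus) for cytotoxicity, read by MTT assay, with a stated time of 24 h (a higher number here means that more compound is tolerated, a lower number that less compound is tolerated), compound 1 (`CC1Cn2c(nc([N+](=O)[O-])c2Br)O1`) gives 9190 nM as its measured value. Compound 2 (`Cc1ccc(-c2c([N+](=O)[O-])nc3n2CC(C)O3)cc1`) reads > 250000 nM as its result, and this is a limit of the assay, not a number. Among the compounds with values here, compound 2 therefore has no exact position on the scale, and no measured step connects it to compound 1. Compound 3 (`CC1Cn2c(nc([N+](=O)[O-])c2-c2ccc(OC(F)(F)F)cc2)O1`) carries trifluoromethoxy in place of methyl on an aromatic carbon of a six-membered aromatic ring of carbon only, para to a large group. Within the data shown here, with no measured step to guide it, the expectation rests on compound 1 at 9190 nM in the same assay, which shows that a compound of this kind can be tolerated less. The estimated move (an at least 2.0-fold lower number from compound 2 to compound 3 (0.31 log units; beyond the scatter)) is downward and moderate in size. Compound 3 is expected at 120000 nM in this assay with an estimated range from 30000 nM up to 250000 nM for that expectation.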

Compound 3, half-maximal cytotoxic concentration: > 125000 nM
Compound 3: a limit, no number; the forecaster's own chance of this, stated with the estimate: 40%; middle value at least 1.0-fold (0.01 log units) from the limit.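

Compound 2 and compound 3 each give a limit of the assay rather than a number, and the step between them cannot be read. The compounds shown leave open whether trifluoromethoxy in place of methyl changes how much compound the cells tolerate, and in which direction.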